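Taking the Phenyl Group Off a Weak Growth Inhibitor

The source may report more compounds than this note shows. Statements on the series, on what has been measured and on what is new or still open speak of the compounds shown alone.

In a functional assay on HeLa cells (Homo sapiens) for antiproliferative activity, read by MTT assay, with a stated time of 48 h (a higher number here means a weaker inhibitor of growth, a lower number a stronger inhibitor of growth), compound 1 `CCOc1cc(NC(=O)CCCCCC(=O)Nc2cc(-c3ccccc3)ccc2N)cc2c1OCC([N+](=O)[O-])=C2` gives 19800 nM. Compound 3 `CCOc1cc(NC(=O)CCCCC(=O)Nc2cc(-c3ccc(C)s3)ccc2N)cc2c1OCC([N+](=O)[O-])=C2` gives 18400 nM, within the usual scatter of compound 1. Compound 2 `CCOc1cc(NC(=O)CCCCCCC(=O)Nc2cc(-c3ccc(C)s3)ccc2N)cc2c1OCC([N+](=O)[O-])=C2` reads > 20000 nM, which is a limit of the assay and not a number.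

Compound 4 `CCOc1cc(NC(=O)CCCCCC(=O)Nc2ccccc2N)cc2c1OCC([N+](=O)[O-])=C2` differs from compound 1 in one place: hydrogen in place of phenyl on an aromatic carbon. Going by the values given here, no measured pair tests this change, so the expectation is loose. With compound 1 at 19800 nM, a moderate fall in the number is expected in this assay, though a step within the scatter remains possible. The expected change is a 2.0-fold lower number from compound 1 to compound 4 (0.30 log units; within the scatter). The estimate for compound 4 is 10000 nM, with an expected range of 3500 nM to 20000 nM.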

Compound 4, concentration for 50% growth inhibition: 14900 nM
Beside the measured number, compound 4's estimate is 1.5-fold (0.17 log units) below it, and the stated range covers the measured number.
By their numbers in this assay, from the lowest: compounds 4, 3 and 1 (each within the scatter of the next). At a limit, above all of these: compound 2.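

Hydrogen in place of phenyl gives a 1.3-fold lower number from compound 1 to compound 4 (0.12 log units; within the scatter). Going by these compounds alone, this is the first direct test of this position, on an aromatic carbon para to an amino group, and in this assay the phenyl group can leave it with no step beyond the scatter. Compound 2 stands as a limit and not a number: the limit of > 20000 nM in this assay, at which 1 of the 4 values shown sits.

On these data alone, whether an amine or a carboxylic acid at this position would move the number beyond the scatter stays open. So does the outcome of the same swap on a longer chain.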